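Adding a Sulfamoyl Group to a Biphenyl Amide

This account rests on a few compounds, and the source may have more. Where it says the series, first, only, none or still open, it means among the compounds named here.

Measured in an assay on isolated protein for binding affinity to serine protease 1 (Homo sapiens); a lower number here means a stronger inhibitor, a higher number a weaker inhibitor:

Compound 1, `CCOC(=O)C(CCc1cccc(C(=N)N)c1)Cn1cnc2cc(C(=N)N)ccc21`: 220 nM
Compound 2, `CCOC(=O)C(CCc1cccc(C(=N)N)c1)Cn1cnc2ccc(C(=N)N)cc21`: 820 nM
Compound 3, `N=C(N)c1ccc2ncn(CC(=O)Nc3ccc(-c4ccccc4)cc3)c2c1`: 480 nM

Compound 3 sits in the middle of these three numbers. Compound 2 and compound 3 lie within the usual scatter of each other, so nothing separates them. Compound 1, however, gives a lower number than compound 3, and that gap lies beyond the scatter, so compound 1 is the stronger binder of those two. Compound 1 and compound 2 share one core and differ only in where one amidine sits; compound 3 carries a different side chain, an amide leading to a biphenyl.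

Compound 4, `N=C(N)c1ccc2ncn(CC(=O)Nc3ccc(-c4ccccc4S(N)(=O)=O)cc3)c2c1`, keeps everything in compound 3 and changes only the outer ring: sulfamoyl in place of hydrogen on an aromatic carbon. Within the data shown here, no pair of measured compounds shows what such a change does in this assay, so there is no measured step to lean on.

With nothing to guide the direction, the expectation is a step from compound 3 to compound 4 of about a 1.2-fold lower number from compound 3 to compound 4 (0.08 log units; within the scatter), not clearly beyond the scatter. Compound 4 is therefore estimated at 400 nM, with a range from 130 nM to 1300 nM.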

Compound 4, inhibition constant: 47 nM
Estimate against measurement, compound 4: 8.5-fold (0.93 log units) above; measured number outside the range, below it.
By their numbers in this assay, from the lowest: compound 4; then compound 1; then compounds 3 and 2 (each within the scatter of the next).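

In this assay the outer ring of the biphenyl amide proves highly responsive to substitution: sulfamoyl in place of hydrogen on an aromatic carbon, ortho to a large group, gives a 10-fold lower number from compound 3 to compound 4 (1.01 log units; beyond the scatter) and counts as a large step. This is the first single change with a measured effect among these compounds, and it shows that adding just 4 heavy atoms at this one position can move the number well beyond the scatter, placing compound 4 lowest of the four. The measurements show the size and direction of this step, but nothing here explains why the number falls so far.

Among these compounds, with only one group tested at this position, it remains open whether the improvement is specific to sulfamoyl or would also appear with an amine, a carboxylic acid or a methyl group in the same place. Also unresolved is whether sulfamoyl would have a similar effect at another carbon of that ring, or on the outer ring of the different side chain carried by compound 1.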